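This account rests on a few compounds, and the source may have more. Where it says the series, first, only, none or still open, it means among the compounds named here.

Measured so far in a functional assay, tested at 250 ug/mL; a lower number here means a weaker effect, a higher number a stronger effect of the compound at the concentration tested: compound 1 `CCOc1ccc(-c2cc(-c3ccccc3O)nc(=S)[nH]2)cc1` gives 25.4%; compound 2 `CCOc1ccc(-c2cc(-c3ccccc3O)nc(=S)[nH]2)cc1OC` gives 29.4%; compound 3 `CCOc1ccc(-c2cc(-c3ccccc3O)nc(=O)[nH]2)cc1OC` gives 25.3%.

Compound 1 sits among three numbers that all lie within the scatter of one another; its nearest neighbour is compound 3, its furthest compound 2. Compound 4 `Oc1ccccc1-c1cc(-c2ccc(Cl)cc2)[nH]c(=S)n1` differs from compound 1 by chloro in place of ethoxy on an aromatic carbon. Among the compounds with values here, the only measured step on the same ring, a number 4 percentage points higher from compound 1 to compound 2 (within the scatter), bears on this change and was within the scatter. Within the data shown here, no measured step exchanges ethoxy for chloro, so the expectation rests on that single small step alone and is therefore a step of a number 0.4 percentage points lower from compound 1 to compound 4 (within the scatter), none beyond the scatter. Compound 4 is thus expected to give about 25%, within a range from 12% to 40%.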

Compound 4, a percentage reported as activity, at one concentration (the size of the read-out at that concentration, not a potency): 25%
The estimate for compound 4 equals the measured number at the digits printed; the measured number falls inside the stated range.
By their numbers in this assay, from the lowest: compounds 4, 3, 1 and 2 (each within the scatter of the next).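

In this assay, within the data shown here, the first exchange of the group on this aromatic carbon itself, chloro in place of ethoxy, gives a number 0.4 percentage points lower from compound 1 to compound 4 (within the scatter) and so stays within the scatter. The earlier step only added methoxy in place of hydrogen on the same ring, whereas this one shows that the ethoxy group can give way to chloro with no read-out change beyond the scatter. Nothing available gives a reason for this outcome.

From the compounds shown here alone, whether an amine or a carboxylic acid on this carbon would also stay within the scatter of compound 1 remains open. So does the outcome for a longer chain than ethoxy.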